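Esterifying the side chain of compound 1

This account rests on a few compounds, and the source may have more. Where it says the series, first, only, none or still open, it means among the compounds named here.

Compound 1 `O=C(CN(c1ncnc2c1ncn2C1CCCCO1)C1CC1)N[C@@H](CO)C(=O)OCc1ccccc1`: 46.7%
Compound 2 `CSCC[C@H](NC(=O)CN(c1nc(Cl)nc2[nH]cnc12)C1CC1)C(=O)O`: 22.8%

In a functional assay on the whole organism (Tail, strain ICR) with Mus musculus as the target, in the tail flick test, with a stated time of 60 min, at a dose of 25 umol/kg by the oral route (on this read-out lower numbers stand for a weaker effect and higher numbers for a stronger effect at the one dose given), compound 1 gives 46.7%, the higher of the two numbers; compound 2 gives 22.8%, a gap beyond the scatter. Compound 3 `O=C(CN(c1ncnc2c1ncn2C1CCCCO1)C1CC1)N[C@@H](CC(=O)OCc1ccccc1)C(=O)OCc1ccccc1` is not yet measured. It differs from compound 1 by benzyloxycarbonyl in place of hydroxy on a saturated chain carbon, two bonds along the chain from an amide-type nitrogen and a carbonyl carbon. For the measured compounds named here, no step between measured compounds covers a change of this kind, so the step is expected to be small, downward or none beyond the scatter: the estimated step is a number 8.7 percentage points lower from compound 1 to compound 3 (within the scatter). Compound 3 is therefore expected to give 38%, within 15% to 60%.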

Compound 3, a percentage reported as activity, at one dose (the size of the read-out at that dose, not a potency): 38.2%
Compound 3: the middle estimate sits 0.2 percentage points below what was measured, and the stated range covers the measured number.
By their numbers in this assay, from the lowest: compound 2; then compounds 3 and 1 (each within the scatter of the next).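

In this assay the step reads a number 8.5 percentage points lower from compound 1 to compound 3 (within the scatter), so this saturated chain carbon takes benzyloxycarbonyl, with its six-membered aromatic ring, in place of hydroxy without a difference beyond the scatter. The hydrogen-bond donor of hydroxy is absent from compound 3, and the read-out stays within the scatter of compound 1. Nothing at hand gives a reason for this result. On these data alone, whether an amine, a carboxylic acid or a longer chain at this carbon would also stay within the scatter remains open.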